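Swapping pyridin-4-yl for pyridin-2-yl in compound 3

The source may hold more compounds than are shown below. What is called first, only, known or untested is meant among the compounds shown, and "the series" means these compounds.

- Compound 1 `CCCc1ccc2[nH]c(-c3ccc4[nH]c(-c5ccc6[nH]cnc6c5)nc4c3)nc2c1`: 7600 nM
- Compound 2 `c1ccc(-c2ccc3[nH]c(-c4ccc5[nH]c(-c6ccc7[nH]cnc7c6)nc5c4)nc3c2)cc1`: 90 nM
- Compound 3 `c1cc(-c2ccc3[nH]c(-c4ccc5[nH]c(-c6ccc7[nH]cnc7c6)nc5c4)nc3c2)ccn1`: 35 nM

In a functional assay on RPMI 8402 cells (Homo sapiens) for cytotoxicity (a higher number here means a weaker inhibitor, a lower number a stronger inhibitor), compound 3 has the lowest number of the three, 35 nM. Compound 4 `c1ccc(-c2ccc3[nH]c(-c4ccc5[nH]c(-c6ccc7[nH]cnc7c6)nc5c4)nc3c2)nc1` differs from it as follows: pyridin-2-yl in place of pyridin-4-yl on an aromatic carbon. In short, pyridin-2-yl stands in place of pyridin-4-yl on an aromatic carbon.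

Replacing propyl with a ring gave large steps: an 84-fold lower number from compound 1 to compound 2 (1.93 log units; beyond the scatter) and a 220-fold lower number from compound 1 to compound 3 (2.34 log units; beyond the scatter). Exchanging one ring for another gave only a modest one: a 2.6-fold lower number from compound 2 to compound 3 (0.41 log units; beyond the scatter). Within the data shown here, compound 4 also exchanges one ring for another, so a modest step is expected in this assay, probably toward a higher number, though no pyridin-2-yl compound has been measured yet. The expected change is a 1.7-fold higher number from compound 3 to compound 4 (0.23 log units; within the scatter). For compound 4 the estimated value is 60 nM, with an expected range of 20 nM to 200 nM.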

Compound 4, half-maximal inhibitory concentration: 160 nM
Beside the measured number, compound 4's estimate is 2.7-fold (0.43 log units) below it, within the range that was stated.
By their numbers in this assay, from the lowest: compound 3; then compounds 2 and 4 (each within the scatter of the next); then compound 1.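

Within a single ring, the place of the nitrogen matters in this assay: the two compounds have the same atoms, joined differently, yet their numbers differ (a 4.6-fold higher number from compound 3 to compound 4 (0.66 log units; beyond the scatter)). Pyridin-2-yl cannot be told apart from phenyl (a 1.8-fold higher number from compound 2 to compound 4 (0.25 log units; within the scatter)), while it still keeps a large gain over propyl (a 48-fold lower number from compound 1 to compound 4 (1.68 log units; beyond the scatter)). Nothing available explains why the nitrogen's place changes the number.

Open, from the compounds shown here alone, is how pyridin-3-yl would compare with these two pyridines at this position. Also open, going by these compounds, is how a ring carrying an amine would behave here.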